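Swapping a bromophenyl for an iodophenyl on the ring amine

The source may report more compounds than this note shows. Statements on the series, on what has been measured and on what is new or still open speak of the compounds shown alone.

Compound 3 `CCCn1c(=O)[nH]c2nc(-c3ccc(S(=O)(=O)N4CCN(c5cccc(Br)c5)CC4)cc3)[nH]c2c1=O` carries a 3-bromophenyl on an amine nitrogen in a ring. In an assay on CHO cells for displacement of a labelled ligand from adenosine receptor A1 (Homo sapiens), read by scintillation counting, with a stated time of 90 min, in the presence of a further agent that is not named here (on this read-out higher numbers stand for weaker inhibition and lower numbers for stronger inhibition), compound 3 gives only a limit, > 1000 nM. Compound 2 `CCCn1c(=O)[nH]c2nc(-c3ccc(S(=O)(=O)N4CCN(c5ccccc5Br)CC4)cc3)[nH]c2c1=O`, with a 2-bromophenyl at that place, also stops at a limit; in this assay compound 2 gives > 1000 nM. Going by the values given here, compound 1 `CCCn1c(=O)[nH]c2nc(-c3ccc(S(=O)(=O)N4CCN(Cc5cccc(C)c5)CC4)cc3)[nH]c2c1=O`, bearing a 3-methylbenzyl there, is the one compound with a number, since in this assay compound 1 gives 795 nM. The steps of an at least 1.2-fold higher number from compound 1 to compound 2 (0.09 log units; that floor lies within the scatter) and an at least 1.2-fold higher number from compound 1 to compound 3 (0.09 log units; that floor lies within the scatter) are floors that lie within the scatter, and the step that the two limits leave unreadable from compound 2 to compound 3 stays unreadable because the limit of > 1000 nM in this assay, at which 2 of the 3 values shown sit, caps both of its ends.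

Compound 4 `CCCn1c(=O)[nH]c2nc(-c3ccc(S(=O)(=O)N4CCN(c5ccc(I)cc5)CC4)cc3)[nH]c2c1=O` differs from compound 3 by 4-iodophenyl in place of 3-bromophenyl on an amine nitrogen in a ring. Among the compounds with values here, the only measured steps touching this position are those floors, so no direction beyond the scatter can be read from them. Compound 4 is therefore expected to sit at or close to the same limit, with an estimated step that the limit leaves unreadable from compound 3 to compound 4. The estimate for compound 4 is 2000 nM, ranging from 700 nM to 6000 nM.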

Compound 4, inhibition constant: > 1000 nM
Compound 4: only a limit was reported (the forecaster's own chance of this, stated with the estimate: 70%); the middle value is on the limit's open side.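

In this assay compound 4 gives > 1000 nM, which is a limit and not a number. Going by these compounds alone, the steps linking compound 4 to compound 2 and to compound 3 cannot be read, and the only readable step is an at least 1.2-fold higher number from compound 1 to compound 4 (0.09 log units; that floor lies within the scatter). A 4-iodophenyl on the ring amine therefore adds a third halogen-bearing phenyl group without a number, so that this position now shows mainly one shared limit: the limit of > 1000 nM in this assay, at which 3 of the 4 values shown sit.

The compounds shown leave open how far any of these halogen-bearing phenyl groups actually lies from the 3-methylbenzyl of compound 1. They also leave open whether a 4-iodobenzyl or a 3-bromobenzyl on the ring amine would give a number rather than a limit in this assay.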